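The compounds below may be only part of what the source reports. "The series", "measured", "known", "first", "only" and "open" are said of these compounds alone.

Of the compounds shown here, three from one series have been tested in the same way. Compound 1 `O=C(Nc1cccc(-n2cc(-c3ccncc3)c(-c3cc(O)cc(Cl)c3)n2)c1)Nc1ccc(Cl)c(C(F)(F)F)c1` carries a hydroxy group on one of its aromatic rings and a urea linker. In a functional assay on KM12 cells (Homo sapiens) for inhibition, read by sulforhodamine B assay, with a stated time of 48 h, tested at 10 uM (a lower number here means a stronger effect, a higher number a weaker effect of the compound at the concentration tested), compound 1 gives 15.1%. Compound 2 `COc1cc(Cl)cc(-c2nn(-c3cccc(NC(=O)Nc4ccc(Cl)c(C(F)(F)F)c4)c3)cc2-c2ccncc2)c1` is the same molecule with one change: methyl in place of hydrogen on an oxygen on an aromatic ring. In this assay compound 2 gives 9.1%. That change gave a number 6 percentage points lower from compound 1 to compound 2 (within the scatter), so the two numbers cannot be told apart here.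

Compound 3 `O=C(Nc1cccc(-n2cc(-c3ccncc3)c(-c3cc(O)cc(Cl)c3)n2)c1)c1cc(C(F)(F)F)cc(C(F)(F)F)c1` keeps the hydroxy group but replaces the urea with an amide that carries two trifluoromethyl groups. In this assay compound 3 gives 21.2%. The difference between the core of compound 3 and the core of compound 1 is not broken down here. The number for compound 3 lies within the scatter of that for compound 1, while the number for compound 2 is lower than that for compound 3 by more than the scatter.

Compound 4 `COc1cc(Cl)cc(-c2nn(-c3cccc(NC(=O)c4cc(C(F)(F)F)cc(C(F)(F)F)c4)c3)cc2-c2ccncc2)c1` has not yet been measured. It stands to compound 3 as compound 2 stands to compound 1: methyl in place of hydrogen on an oxygen on an aromatic ring. Among the measured compounds shown here, the same kind of change, at the same place, is the one already seen between compound 1 and compound 2. On the strength of that earlier step a number 6 percentage points lower from compound 1 to compound 2 (within the scatter), the expected step is a number 6.2 percentage points lower from compound 3 to compound 4 (within the scatter), a small one. Compound 4 is therefore estimated at 15%, likely between 5% and 28%.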

Compound 4, a percentage reported as activity, at one concentration (the size of the read-out at that concentration, not a potency): 55.5%
The estimate for compound 4 lay 40.5 percentage points below the measured number; measured number outside the range, above it.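

On the core of compound 3, which carries the amide, the change from hydroxy to methoxy gives a number 34.3 percentage points higher from compound 3 to compound 4 (beyond the scatter), so in this assay the methoxy compound has the clearly weaker effect at the concentration tested. Among the compounds shown here, the size of this step, and even its direction, did not carry over from the core with the urea to the core with the amide: the same change on two cores in this assay, a number 6 percentage points lower (within the scatter) from compound 1 to compound 2 and a number 34.3 percentage points higher (beyond the scatter) from compound 3 to compound 4, 40.3 percentage points apart, beyond the scatter of two such steps With only two pairs, this shows that a step measured on one core is not a safe guide to the same change on the other, but it does not show which difference between the cores matters, the linker or the groups on the far ring, nor does it give a rule for any further core.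

The compounds shown have only hydroxy or methoxy at this place, so it remains open how an ethoxy group, a longer chain on the oxygen or an amine in place of the hydroxy would behave on either core. A hydroxy and methoxy pair with the urea joined to the bis(trifluoromethyl)phenyl ring, or with the amide joined to the chloro and trifluoromethyl ring, could help separate the effect of the linker from that of the far ring.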